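The source may report more compounds than this note shows. Statements on the series, on what has been measured and on what is new or still open speak of the compounds shown alone.

Compound 1 `Cc1ccc(CN2CCC=C(CCC(=O)NO)C2=O)cc1`: 1430 nM
Compound 2 `Cc1cccc(CN2CCC=C(CCC(=O)NO)C2=O)c1`: 8120 nM
Compound 3 `Cc1ccccc1CN1CCC=C(CCC(=O)NO)C1=O`: 4920 nM

In a functional assay on MDA-MB-231 cells (Homo sapiens) for inhibition, read by sulforhodamine B assay (a higher number here means a weaker inhibitor of growth, a lower number a stronger inhibitor of growth), compound 1 holds the lowest number of the three and is the strongest inhibitor of growth among them. Putting 3-methylphenyl in its place gives a 5.7-fold higher number from compound 1 to compound 2 (0.75 log units; beyond the scatter) and putting 2-methylphenyl there gives a 3.4-fold higher number from compound 1 to compound 3 (0.54 log units; beyond the scatter) as modest steps beyond the scatter. The remaining step (a 1.7-fold lower number from compound 2 to compound 3 (0.22 log units; within the scatter)) lies within the scatter.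

Compound 4 `O=C(CCC1=CCCN(Cc2ccc([N+](=O)[O-])cc2)C1=O)NO` has not yet been measured. It carries nitro in place of methyl on an aromatic carbon, para to a large group (nitro in place of methyl on an aromatic carbon). For the measured compounds named here, no measured step replaces the methyl itself, so the modest steps from compound 1 (a 5.7-fold higher number from compound 1 to compound 2 (0.75 log units; beyond the scatter) and a 3.4-fold higher number from compound 1 to compound 3 (0.54 log units; beyond the scatter)) are only an indirect guide to size. A modest step in this assay toward a higher number is therefore expected, though the direction remains uncertain. The estimated change is a 1.6-fold higher number from compound 1 to compound 4 (0.21 log units; within the scatter) and may prove smaller. For compound 4 the estimated value is 2300 nM (expected range 750 nM to 7000 nM).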

Compound 4, concentration for 50% growth inhibition: 470 nM
Compound 4: the middle estimate sits 4.9-fold (0.69 log units) above what was measured; the measured number lies below the stated range.
By their numbers in this assay, from the lowest: compound 4; then compound 1; then compounds 3 and 2 (each within the scatter of the next).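

In this assay, for the compounds shown here, the replacement of methyl by nitro on the aromatic carbon para to a large group gives a 3.0-fold lower number from compound 1 to compound 4 (0.48 log units; beyond the scatter) and is the first measured step that changes the group itself and not just where the methyl sits. Compound 2 and compound 3 had shown only higher numbers than compound 1 when the methyl stood elsewhere, whereas compound 4 shows that a change at this carbon can also lower the number beyond the scatter. No measurement at hand explains this step.

The compounds shown leave open whether the lower number is particular to nitro or would also come with a nitrile, a trifluoromethyl group or an amine on the same carbon. Nor do they tell whether nitro would keep this step in the places held by the methyl of compound 2 and compound 3.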